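The source may report more compounds than this note shows. Statements on the series, on what has been measured and on what is new or still open speak of the compounds shown alone.

Compound 1 `C=C[C@@](C)(/C=C/c1ccc(OC(=O)CC)cc1)CCC=C(C)C` gives 63%
Compound 2 `C=C[C@@](C)(/C=C/c1ccc(OC(=O)CCCCCCC)cc1)CCC=C(C)C` gives 51%

Within the data shown here, in a functional assay on IMR-32 cells (Homo sapiens) for inhibition, with a stated time of 48 h, tested at 50 uM (on this read-out higher numbers stand for more inhibition of growth at the one concentration tested and lower numbers for less inhibition of growth), compound 2 holds the lower of the two numbers, and compound 1 is its only neighbour. Compound 3 `C=C[C@@](C)(/C=C/c1ccc(OC(=O)CCCCCCCCC)cc1)CCC=C(C)C` differs from compound 2 by ethyl in place of hydrogen on a saturated chain carbon, seven bonds along the chain from a carbonyl carbon on the same ester chain. Among the measured compounds shown here, only one measured step bears on this: a number 12 percentage points lower from compound 1 to compound 2 (beyond the scatter) for pentyl in place of hydrogen, a modest fall beyond the scatter. A single step sets no firm trend, and the ethyl addition is the smaller one. The expected change is therefore small and probably within the scatter, an estimated a number 5 percentage points lower from compound 2 to compound 3 (within the scatter) in the same direction. Compound 3 is expected at about 46% (estimated range 34% to 58%).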

Compound 3, percent growth inhibition at one concentration: 52%
Compound 3: the middle estimate sits 6 percentage points below what was measured; low and high end bracket the measured number.
By their numbers in this assay, from the lowest: compounds 2 and 3 (each within the scatter of the next); then compound 1.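

In this assay, ethyl in place of hydrogen on a saturated chain carbon, seven bonds along the chain from a carbonyl carbon, gives a number 1 percentage points higher from compound 2 to compound 3 (within the scatter), so the fall seen with the earlier pentyl addition does not continue at this place. Against the shorter ester chain, the heptyl change still gives a number 11 percentage points lower from compound 1 to compound 3 (beyond the scatter). Nothing available explains this levelling. Still open, as far as these compounds go, is how an acetate, a much longer chain, or an amine or carboxylic acid at the chain end would fare.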